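This account rests on a few compounds, and the source may have more. Where it says the series, first, only, none or still open, it means among the compounds named here.

Measured so far:
compound 1 `OC[C@H]1O[C@@H](n2cnc3c(NCc4ccccc4Cl)ncnc32)[C@H](O)[C@@H]1O` — > 166000 nM
compound 2 `OC[C@H]1O[C@@H](n2cnc3c(NCc4ccc(Br)cc4)ncnc32)[C@H](O)[C@@H]1O` — > 166000 nM
compound 3 `OC[C@H]1O[C@@H](n2cnc3c(NCc4ccc(Cl)cc4Cl)ncnc32)[C@H](O)[C@@H]1O` — > 166000 nM

Series notes. In a functional assay on B16 cells (Mus musculus) for antiproliferative activity, with a stated time of 72 h (on this read-out lower numbers stand for stronger inhibition and higher numbers for weaker inhibition), compound 1 gives > 166000 nM, which is a limit of the assay and not a number. Compound 2 gives > 166000 nM, likewise a limit. Compound 3 gives > 166000 nM, again a limit. Going by the values given here, all three values therefore sit together at the limit of > 166000 nM in this assay, at which 3 of the 3 values shown sit, so none of the benzyl variations so far has moved the read-out into the measurable range.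

Where compound 2 stands: at the limit, with no number to place it against the other two. The measured steps between the three compounds are all unreadable for the same reason: a step that the two limits leave unreadable from compound 1 to compound 2, a step that the two limits leave unreadable from compound 1 to compound 3 and a step that the two limits leave unreadable from compound 2 to compound 3.

The next compound, compound 4 `OC[C@H]1O[C@@H](n2cnc3c(NCc4ccc(F)cc4F)ncnc32)[C@H](O)[C@@H]1O`, differs from compound 2 by 2,4-difluorophenyl in place of 4-bromophenyl on a saturated chain carbon bound to a nitrogen on an aromatic ring. Among the compounds with values here, the only steps that bear on this change are the three unreadable ones above, none of which gives a size or a direction. Nothing in the measured data suggests the read-out would leave the limit, so no step beyond the scatter is expected; compound 4 is expected to report a limit as well, and the step of a number no higher from compound 2 to compound 4 (the limit leaves the size open) is estimated at no change.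

Estimate for compound 4: 166000 nM, with a range from 60000 nM to 500000 nM, most likely returned as a limit.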

Compound 4, half-maximal inhibitory concentration: > 166000 nM
Compound 4 ended at the assay's limit (the forecaster's own chance of this, stated with the estimate: 85%); the middle value lies on the limit itself.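

In this assay compound 4 gives > 166000 nM, which is a limit and not a number. No step linking compound 4 with compound 1, compound 2 or compound 3 can be read, and the series stands thus: the limit of > 166000 nM in this assay, at which 4 of the 4 values shown sit.

The compounds shown leave open whether any benzyl variation on the shared core reaches the measurable range, and how far these four differ.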